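Shortening the chain of compound 2

The source may report more compounds than this note shows. Statements on the series, on what has been measured and on what is new or still open speak of the compounds shown alone.

Compound 1 `CCCCc1cc2cn(COCCO)c(=O)nc2o1` with > 200000 nM as a limit
Compound 2 `CCCCCCCc1cc2cn(COCCO)c(O)nc-2n1` with 119000 nM as a number
Compound 3 `CCCCCCCCCc1cc2cn(COCCO)c(=O)nc2o1` with >= 100000 nM as a limit

In a functional assay on HEL cells (Homo sapiens) (on this read-out lower numbers stand for higher toxicity in this test and higher numbers for lower toxicity in this test), compound 2 gives 119000 nM as the only number shown. The other two values are limits. Compound 4 `CCCCCc1cc2cn(COCCO)c(O)nc-2n1` differs from compound 2 by hydrogen in place of ethyl on a saturated chain carbon, five bonds along the chain from an aromatic carbon in one place, hydrogen in place of ethyl on a saturated chain carbon, five bonds along the chain from an aromatic carbon. Among the compounds with values here, the only measured step that bears on this is a step that the two limits leave unreadable from compound 1 to compound 3 and it has another core and no readable size. Compound 1 stands at the limit of > 200000 nM in this assay, at which 1 of the 3 values shown sits, as a limit. Compound 3 stands at the limit of >= 100000 nM in this assay, at which 1 of the 3 values shown sits, as a limit. In this assay no step beyond the scatter is therefore expected. Compound 4 is expected at 150000 nM with an estimated range (70000 nM to 280000 nM). The estimate amounts to a 1.3-fold higher number from compound 2 to compound 4 (0.10 log units; within the scatter) as the expected change.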

Compound 4, half-maximal cytotoxic concentration: > 200000 nM
Compound 4: no number, only a limit (the forecaster's own chance of this, stated with the estimate: 50%); at least 1.3-fold (0.12 log units) between middle value and limit.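

Within one core, hydrogen in place of ethyl on a saturated chain carbon, five bonds along the chain from an aromatic carbon, gives the first step that can be read in this assay: an at least 1.6-fold higher number from compound 2 to compound 4 (0.22 log units; that floor lies within the scatter). Compound 4 stands at a limit and not at a number: the limit of > 200000 nM in this assay, at which 2 of the 4 values shown sit. The earlier step on the other core cannot be read, so this floor is the only size available for shortening a chain.

As far as these compounds go, the true size of this step stays open, including whether it goes beyond the scatter. The compounds shown also leave open how a chain carrying an amine would read in this assay.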